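Adding a Phenyl to a Compound Known Only by a Limit

The source may report more compounds than this note shows. Statements on the series, on what has been measured and on what is new or still open speak of the compounds shown alone.

Measured so far in a functional assay on HOS cells (Homo sapiens) for antiproliferative activity, read by sulforhodamine B assay; on this read-out higher numbers stand for weaker inhibition of growth and lower numbers for stronger inhibition of growth:
Compound 1 `OC[C@H]1O[C@@H](Cc2ccccc2)[C@H](O)[C@@H](OCc2ccccc2)[C@@H]1OCc1ccccc1` gives 31600 nM as a number.
Compound 2 `C[C@@H]1O[C@H](COCc2ccccc2)[C@@H](OCc2ccccc2)[C@H](OCc2ccccc2)C1=O` gives > 50000 nM as a limit.

For the measured compounds named here, only two compounds have been tested on these cells, and neither shows much inhibition of growth. On these data alone, compound 2 stands at the limit of > 50000 nM in this assay, at which 1 of the 2 values shown sits, and has no number of its own, so its true position remains open.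

The next compound is compound 3 `O=C1[C@H](Cc2ccccc2)O[C@H](COCc2ccccc2)[C@@H](OCc2ccccc2)[C@@H]1OCc1ccccc1`, not yet measured. Its difference from compound 2 is phenyl in place of hydrogen on a saturated chain carbon bound to a saturated ring carbon. Cut one bond further out, the same change reads methyl to benzyl.

Going by the values given here, no measured step shows what this change does in this assay, so the expectation is weak. Compound 1 also carries a benzyl group and gives a number (31600 nM), which suggests a modest step towards stronger inhibition of growth rather than a large one. The estimate means an expected at least 1.7-fold lower number from compound 2 to compound 3 (0.25 log units; that floor lies within the scatter) and no more. Compound 3 is estimated at 28000 nM, with an expected range from 10000 nM to 50000 nM, and it may yet return only a limit.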

Compound 3, concentration for 50% growth inhibition: > 50000 nM
Compound 3 ended at the assay's limit; the forecaster's own chance of this, stated with the estimate: 30%; at least 1.7-fold (0.25 log units) between middle value and limit.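

In this assay compound 3 gives > 50000 nM, which is a limit and not a number. No step from compound 2 to compound 3 can be read, because both compounds stop at the same limit: the limit of > 50000 nM in this assay, at which 2 of the 3 values shown sit.

On these data alone, whether phenyl in place of hydrogen at this place changes growth inhibition in this assay, and in which direction, stays open.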